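Notes on the nitrogen substituent of the shared core

A few compounds are considered here, and "the series" means these few. Any claim that something is new, unique, unknown or untested is made for them only; others in the source may bear on it.

Compound 1, `Nc1ncnc2c1c(-c1cc(C3CC3)on1)nn2C1CCCCC1`, 290 nM
Compound 2, `CC(C)(O)Cn1nc(-c2cc(C3CC3)on2)c2c(N)ncnc21`, 4250 nM
Compound 3, `CCCCCCCn1nc(-c2cc(C3CC3)on2)c2c(N)ncnc21`, > 10000 nM

Three compounds share one core and differ only in the group on the aromatic nitrogen. In an assay on TT cells for inhibition of proto-oncogene tyrosine-protein kinase receptor Ret variant C634W (Homo sapiens), read by MTT assay, with a stated time of 10 days (on this read-out higher numbers stand for weaker inhibition of growth and lower numbers for stronger inhibition of growth), compound 1 gives 290 nM. In this assay compound 2 gives 4250 nM. For compound 3 the reading > 10000 nM is a limit of this assay and not a number. Compound 3 thus stands weakest of the three, since the steps of an at least 34-fold higher number from compound 1 to compound 3 (1.53 log units; beyond the scatter) and an at least 2.3-fold higher number from compound 2 to compound 3 (0.37 log units; beyond the scatter) both go beyond the scatter; the reading rests on (the limit of > 10000 nM in this assay, at which 1 of the 3 values shown sits).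

Compound 4, `Cn1nc(-c2cc(C3CC3)on2)c2c(N)ncnc21`, carries hydrogen in place of hexyl on a saturated chain carbon bound to an aromatic nitrogen. Within the data shown here, the steps that bear on this change both end at compound 3: the large rise an at least 34-fold higher number from compound 1 to compound 3 (1.53 log units; beyond the scatter) and the rise an at least 2.3-fold higher number from compound 2 to compound 3 (0.37 log units; beyond the scatter), each in the direction of weaker growth inhibition as the nitrogen group grows longer. Cutting the chain back to methyl walks the opposite way, so a fall in this assay is expected, of a size between those two steps, read as an at least 3.3-fold lower number from compound 3 to compound 4 (0.52 log units; beyond the scatter). Among the measured compounds shown here, no compound with a group as small as methyl has been measured, so the spread is wide. The estimate for compound 4 is 3000 nM, expected to lie between 600 nM and 12000 nM.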

Compound 4, concentration for 50% growth inhibition: 3510 nM
Compound 4: the middle estimate sits 1.2-fold (0.07 log units) below what was measured; the range from low to high includes it.
By their numbers in this assay, from the lowest: compound 1; then compounds 4 and 2 (each within the scatter of the next). At a limit, above all of these: compound 3.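

The step to methyl adds something the chain compounds could not: in this assay, a 12-fold higher number from compound 1 to compound 4 (1.08 log units; beyond the scatter), so removing the hexyl portion of the heptyl group does not bring the reading back to that of the cyclohexyl group, and among the four compounds shown, compound 1, with cyclohexyl, stands strongest. Methyl and 2-hydroxy-2-methylpropyl cannot be told apart on this read-out, with a 1.2-fold lower number from compound 2 to compound 4 (0.08 log units; within the scatter), so the added hydroxy-bearing carbons of compound 2 show no separable change from the plain methyl of compound 4. At the long end, the chain does separate from methyl, with an at least 2.8-fold lower number from compound 3 to compound 4 (0.45 log units; beyond the scatter), but the reading for compound 3 is a limit and not a number, so this step gives only a bound: the limit of > 10000 nM in this assay, at which 1 of the 4 values shown sits.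

On these data alone, how the reading moves across unbranched chains of intermediate length, such as ethyl, propyl or butyl, remains open. Also open, as far as these compounds go, is whether the cyclohexyl result extends to other rings on the aromatic nitrogen, such as cyclopentyl, phenyl or piperidine.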